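From Hydroxy to a Boron Group in Antiproliferative Potency

The compounds below may be only part of what the source reports. "The series", "measured", "known", "first", "only" and "open" are said of these compounds alone.

In a functional assay on A2780 cells (Homo sapiens) for antiproliferative activity, read by sulforhodamine B assay, with a stated time of 48 h (a higher number here means a weaker inhibitor, a lower number a stronger inhibitor), compound 1 (`COc1ccc(/C=C/C(=O)c2ccccc2-c2ccc(F)cc2)cc1`) gives 170 nM, while compound 2 (`COc1ccc(/C=C/C(=O)c2ccccc2-c2ccc(F)cc2)cc1O`) gives 27 nM. Compound 2 thus holds the lower of the two numbers and is the stronger inhibitor of the pair. Compound 3 (`COc1ccc(/C=C/C(=O)c2ccccc2-c2ccc(F)cc2)cc1B(O)O`) has not yet been measured. It differs from compound 2 at the carbon that carries the hydroxy: a group of 3 heavy atoms (1 boron, 2 oxygen; no ring) in place of one oxygen atom, on an aromatic carbon. The new group stands on an aromatic carbon, ortho to a methoxy group and meta to a large group.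

For the measured compounds named here, only one measured step bears on this change: a 6.3-fold lower number from compound 1 to compound 2 (0.80 log units; beyond the scatter), where hydroxy replaces hydrogen at that same carbon. Going by the values given here, this shows that the place responds to substitution, but no measured compound carries boron, so the data give only weak guidance. Some of the gain seen in compound 2 may be kept, and a partial loss seems more likely than a further gain. The expected change in this assay is a 2.2-fold higher number from compound 2 to compound 3 (0.35 log units; beyond the scatter), smaller than the measured step. Compound 3 is estimated at 60 nM, with an expected range from 12 nM to 300 nM.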

Compound 3, half-maximal inhibitory concentration: 63 nM
For compound 3 the middle estimate is 1.1-fold (0.02 log units) below the measured one, and the stated range covers the measured number.
By their numbers in this assay, from the lowest: compound 2; then compound 3; then compound 1.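

In this assay the boron group keeps part of the gain that hydroxy brought at this carbon: replacing hydroxy with it gives a 2.3-fold higher number from compound 2 to compound 3 (0.37 log units; beyond the scatter) in the assay, while replacing the hydrogen of the unsubstituted parent gives a 2.7-fold lower number from compound 1 to compound 3 (0.43 log units; beyond the scatter) at the same place. This shows that the response at this carbon is not confined to hydroxy, since a second group, with 3 heavy atoms rather than 1, also gives a lower number than hydrogen, although it does not match hydroxy. The order of the three compounds therefore places both substituted compounds ahead of compound 1, but no measured property here accounts for the gap between the two groups.

The compounds shown leave open whether other groups on this carbon, such as an amine or a carboxylic acid, would also keep the gain over hydrogen or would match hydroxy. They also leave open whether the boron group would keep its standing if the methoxy group ortho to it gave way to an ethoxy group.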